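Carbamate to Nitrobenzamide on a Sulfonyl Imidazolidinone Core

This account rests on a few compounds, and the source may have more. Where it says the series, first, only, none or still open, it means among the compounds named here.

Compound 1 `CCc1cc(S(=O)(=O)N2C[C@H](c3ccccc3)NC2=O)ccc1NC(=O)OC` gives 200 nM in a functional assay on HCT-116 cells (Homo sapiens) for cytotoxicity, read by MTT assay (on this read-out lower numbers stand for stronger inhibition and higher numbers for weaker inhibition), and compound 2 `CCCCOC(=O)Nc1ccc(S(=O)(=O)N2C[C@H](c3ccccc3)NC2=O)cc1CC` gives 200 nM, so compound 2 stands level with compound 1, the step of no change at the digits printed from compound 1 to compound 2 (within the scatter). Compound 3 `CCc1cc(S(=O)(=O)N2C[C@H](c3ccccc3)NC2=O)ccc1NC(=O)c1ccc([N+](=O)[O-])cc1` carries a different change, (4-nitrophenyl in place of butoxy on a carbonyl carbon). Going by the values given here, only the single measured step bears on it, and it shows a longer chain on that oxygen leaving activity unchanged; nothing measured here covers an aromatic replacement, so an estimated step of a 1.5-fold higher number from compound 2 to compound 3 (0.18 log units; within the scatter) is given with wide uncertainty. Compound 3 is expected to give 300 nM, within 100 nM to 1500 nM.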

Compound 3, half-maximal inhibitory concentration: 500 nM
The estimate for compound 3 lay 1.7-fold (0.22 log units) below the measured number, within the range that was stated.
By their numbers in this assay, from the lowest: compounds 1 and 2 (each within the scatter of the next); then compound 3.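

Replacing the alkoxy group on this carbonyl carbon with an aromatic group moves the number in this assay where lengthening the alkoxy chain did not, giving a 2.5-fold higher number from compound 2 to compound 3 (0.40 log units; beyond the scatter) and a 2.5-fold higher number from compound 1 to compound 3 (0.40 log units; beyond the scatter) for 4-nitrophenyl in place of butoxy and methoxy. The position therefore accepts both alkoxy groups without a change in the number, but the 4-nitrophenyl amide gives a modestly higher number. No evidence at hand accounts for this shift.

On these data alone, whether the shift belongs to the ring or to its nitro group stays open. An unsubstituted phenyl or a 4-aminophenyl group on the same carbonyl carbon would separate the two.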